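A few compounds are considered here, and "the series" means these few. Any claim that something is new, unique, unknown or untested is made for them only; others in the source may bear on it.

Measured compounds:
compound 1, `Cc1cc(NC(=O)Cn2nnc(-c3ccccc3)n2)n(C2CCOCC2)n1`: 115%
compound 2, `Cc1cc(NC(=O)Cn2nnc(-c3ccccc3)n2)n(C(C)C)n1`: 107%

In an assay on HEK293 cells for activation of Kir3.1/Kir3.2 (Homo sapiens), read by thallium flux (a lower number here means a smaller maximal response, a higher number a larger maximal response), compound 1 gives 115% and, in a separate run of this assay, compound 2 gives 107%. Compound 2 holds the lower of the two numbers, but the difference a number 8 percentage points lower from compound 1 to compound 2 (within the scatter) lies within the scatter, so the two compounds cannot be told apart in this assay.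

Compound 3, `Cc1cc(NC(=O)Cn2nnc(-c3ccccc3)n2)n(C2CC2)n1`, is still to be measured. It differs from compound 2 as follows: cyclopropyl in place of isopropyl on an aromatic nitrogen

Among the compounds with values here, the only measured step that bears on this change is the earlier exchange of groups on the same aromatic nitrogen, a number 8 percentage points lower from compound 1 to compound 2 (within the scatter), which stayed within the scatter. On that basis compound 3 is expected to show no step beyond the scatter in this assay, and the estimated step is a number 1 percentage points higher from compound 2 to compound 3 (within the scatter). Compound 3 is therefore estimated at 108%, within a range from 95% to 122%.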

Compound 3, largest response reached (Emax), in percent of the reference or control that the assay uses: > 78%
Compound 3: no number, only a limit (the forecaster's own chance of this, stated with the estimate: 2%); the middle value is on the limit's open side.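

In this assay compound 3 gives > 78% which is a limit and not a number. The steps to compound 3 from compound 1 and compound 2 therefore cannot be read. On these data alone, whether cyclopropyl on the aromatic nitrogen gives a maximal response matching that of isopropyl or oxan-4-yl remains open.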